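Trimming the Sulfonamide on a Phenoxyacetic Acid Ligand

The source may report more compounds than this note shows. Statements on the series, on what has been measured and on what is new or still open speak of the compounds shown alone.

Three measured compounds share one core: an acid-bearing side chain and a chlorine on one ring, an alkyne linking it to a second aromatic ring. Compound 1 `Cc1ccc(S(=O)(=O)NC(C)C)cc1C#Cc1cc(Cl)ccc1OCC(=O)O` carries an isopropylsulfamoyl group and a methyl on that second ring. In an assay on CHO cells for displacement of a labelled ligand from prostaglandin D2 receptor 2 (Homo sapiens), read by scintillation counting (on this read-out lower numbers stand for stronger inhibition and higher numbers for weaker inhibition), compound 1 gives 3.4 nM, the lowest of the three numbers. Compound 2 `CN(c1cccc(C#Cc2cc(Cl)ccc2OCC(=O)O)c1)S(C)(=O)=O` gives 122 nM, and compound 3 `COc1ccccc1C#Cc1cc(Cl)ccc1OCC(=O)O` gives 190 nM; both sit far above compound 1, well beyond the scatter of repeated runs.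

Compound 4 `Cc1ccc(S(C)(=O)=O)cc1C#Cc1cc(Cl)ccc1OCC(=O)O` is not yet measured. It differs from compound 1 in one place: methyl in place of isopropylamino on a sulfonyl sulfur. The single hydrogen-bond donor of the isopropylamino group is lost. Within the data shown here, no measured pair shows this exact change, so the expectation leans on the weaker showing of the other two compounds, which lack such a donor as well. The step of a 4.4-fold higher number from compound 1 to compound 4 (0.64 log units; beyond the scatter) is expected to be a loss, beyond the scatter but not dramatic. Compound 4 is therefore expected to give 15 nM, within a range from 4 nM to 60 nM.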

Compound 4, inhibition constant: 5 nM
Beside the measured number, compound 4's estimate is 3.0-fold (0.48 log units) above it; the measured number falls inside the stated range.
By their numbers in this assay, from the lowest: compounds 1 and 4 (each within the scatter of the next); then compounds 2 and 3 (each within the scatter of the next).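

In this assay, putting methyl in place of isopropylamino on a sulfonyl sulfur gives a 1.5-fold higher number from compound 1 to compound 4 (0.17 log units; within the scatter), so the two compounds cannot be told apart. At this position, then, the read-out does not depend on the isopropylamino group or on its hydrogen-bond donor, and a single methyl serves as well, at least on the core of compound 1. Nothing on hand explains why the swap leaves the number within the scatter.

Going by these compounds, whether a plain amino group, an ethyl group or a longer chain on the sulfonyl sulfur would fit as well remains open. So does the share of the sulfonyl group itself and of the methyl on the second ring, since no pair shown changes either of them alone.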